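This account rests on a few compounds, and the source may have more. Where it says the series, first, only, none or still open, it means among the compounds named here.

Measured so far:
compound 1 `O=C(O)CC1CCCC1Cc1ccc(OCc2ccc3ccccc3n2)cc1`, 100 nM
compound 2 `O=C(O)CCC(Cc1ccc(OCc2ccc3ccccc3n2)cc1)c1ccccc1`, 31 nM
compound 3 `CC(CCC(=O)O)Cc1cccc(OCc2ccc3ccccc3n2)c1`, 140 nM

All three were tested in an assay on membranes from lung (Cavia porcellus) for binding affinity to cysteinyl leukotriene receptor (Homo sapiens); a higher number here means a weaker inhibitor, a lower number a stronger inhibitor. Compound 3 gives the highest number of the three; against compound 1 the gap lies within the scatter, so the two cannot be told apart, while compound 2 gives a clearly lower number, beyond the scatter. Compound 4 `O=C(O)CCCCc1cccc(OCc2ccc3ccccc3n2)c1` has not been measured. It differs from compound 3 in one place: hydrogen in place of methyl on a saturated chain carbon bound to two saturated chain carbons. Within the data shown here, with no measured pair of this kind to lean on, the expected step from compound 3 to compound 4 in this assay is a 1.8-fold higher number from compound 3 to compound 4 (0.25 log units; within the scatter), a modest weakening. Compound 4 is therefore estimated at 250 nM, with a range from 100 nM to 700 nM.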

Compound 4, inhibition constant: 100 nM
Compound 4: the middle estimate sits 2.5-fold (0.40 log units) above what was measured; measured number inside the range.
By their numbers in this assay, from the lowest: compound 2; then compounds 1, 4 and 3 (each within the scatter of the next).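

In this assay, hydrogen in place of methyl on a saturated chain carbon bound to two saturated chain carbons gives a 1.4-fold lower number from compound 3 to compound 4 (0.15 log units; within the scatter). This first measured pair of its kind shows that, in this setting, compounds with and without the methyl cannot be told apart, so the methyl brings no measurable gain in binding. No available evidence explains this result. The compounds shown leave open whether an ethyl or a hydroxyl group on this same carbon would move the number beyond the scatter.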